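This account rests on a few compounds, and the source may have more. Where it says the series, first, only, none or still open, it means among the compounds named here.

Measured in a physicochemical assay for solubility, read by HPLC, using the shake flask method, measured as kinetic solubility, with a stated time of 2 h, at pH 7.4; on this read-out higher numbers stand for higher solubility and lower numbers for lower solubility:
Compound 1 `Cc1cc(NCc2cccnc2)n2nc(C)c(-c3ccccc3)c2n1` gives 110000 nM.
Compound 2 `Cc1cccc(CNc2cc(C)nc3c(-c4ccccc4)c(C)nn23)n1` gives < 5000 nM, which is a limit of the assay rather than a number.
Compound 3 `Cc1cc(NCc2nccs2)n2nc(C)c(-c3ccccc3)c2n1` gives 108000 nM.

Compound 3 and compound 1 sit within the usual scatter of each other. Compound 2 stands apart, since its value is a limit (the limit of < 5000 nM in this assay, at which 1 of the 3 values shown sits). Compound 4 `Cc1cc(NCc2ncnn2C)n2nc(C)c(-c3ccccc3)c2n1` differs from compound 3 in one place: 1-methyl-1H-1,2,4-triazol-5-yl in place of 1,3-thiazol-2-yl on a saturated chain carbon bound to a nitrogen on an aromatic ring.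

Within the data shown here, three measured steps touch this position. The step of a 1.0-fold lower number from compound 1 to compound 3 (0.01 log units; within the scatter) is the closest in kind, swapping one aromatic ring on the same chain carbon for another, and it produced no shift beyond the scatter. The steps of an at least 22-fold lower number from compound 1 to compound 2 (1.34 log units; beyond the scatter) and an at least 21-fold higher number from compound 2 to compound 3 (1.33 log units; beyond the scatter) show that a change at this same place can nonetheless move the read-out a long way, though each of these rests on a value that is only a limit. With compound 4 again carrying a small aromatic ring bound to that chain carbon, the expected step is a 1.3-fold lower number from compound 3 to compound 4 (0.10 log units; within the scatter), not beyond the scatter or at most slightly downward. Compound 4 is therefore estimated at 85000 nM, within 25000 nM to 160000 nM.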

Compound 4, solubility: 185000 nM
Compound 4: the middle estimate sits 2.2-fold (0.34 log units) below what was measured; the measured number lies above the stated range.
By their numbers in this assay, from the lowest: compounds 3, 1 and 4 (each within the scatter of the next). At a limit, below all of these: compound 2.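

In this assay, a third kind of small aromatic ring on the saturated chain carbon joins the earlier two at one level: the step of a 1.7-fold higher number from compound 3 to compound 4 (0.23 log units; within the scatter) and the step of a 1.7-fold higher number from compound 1 to compound 4 (0.23 log units; within the scatter) both leave compounds 1, 3 and 4 indistinguishable, even though 1-methyl-1H-1,2,4-triazol-5-yl has more ring hetero atoms than 1,3-thiazol-2-yl and a methyl group of its own. Among these compounds, compound 4 thus shows that a methyl on the ring does not always come with a reading as low as that of compound 2, the one compound here that goes against the shared level, and the step is an at least 37-fold higher number from compound 2 to compound 4 (1.56 log units; beyond the scatter). The value of compound 2 is a limit and not a number, so the true size of that step stays unknown: the limit of < 5000 nM in this assay, at which 1 of the 4 values shown sits.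

As far as these compounds go, it remains open whether the low reading of compound 2 goes with its methyl group or with the pyridin-2-yl ring itself, a question that a plain pyridin-2-yl group would help to settle. From the compounds shown here alone, it is also open whether this level would hold for a non-aromatic group on the same chain carbon, such as a morpholine or a simple amine.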